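Oral exposure across the aryl variants of the shared core

This account rests on a few compounds, and the source may have more. Where it says the series, first, only, none or still open, it means among the compounds named here.

Measured so far:
compound 1 `CN1CCN(CCCS(=O)(=O)c2ccc3nc(NC(=O)NC(=O)c4cccc(-n5cccn5)c4Cl)sc3c2)CC1`: 12 nM
compound 2 `CN1CCN(CCCS(=O)(=O)c2ccc3nc(NC(=O)NC(=O)c4cc(C5CC5)ccc4Cl)sc3c2)CC1`: 1400 nM
compound 3 `CN1CCN(CCCS(=O)(=O)c2ccc3nc(NC(=O)NC(=O)c4cc(N5CCCC5)ccc4Cl)sc3c2)CC1`: 640 nM

In an ADME assay on the whole organism (strain Han-Wistar) for pharmacokinetics, with Rattus norvegicus as the target, read by LC-MS, at a dose of 2 mg/kg by the oral route (on this read-out lower numbers stand for lower exposure and higher numbers for higher exposure at the dose given), compound 3 stands second highest of the three numbers; the nearer step is a 2.2-fold lower number from compound 2 to compound 3 (0.34 log units; beyond the scatter), and the further step is a 53-fold higher number from compound 1 to compound 3 (1.73 log units; beyond the scatter). Compound 4 `CN1CCN(CCCS(=O)(=O)c2ccc3nc(NC(=O)NC(=O)c4cc5c(ccn5C)cc4Cl)sc3c2)CC1` carries 5-chloro-1-methyl-1H-indol-6-yl in place of 2-chloro-5-(pyrrolidin-1-yl)phenyl on a carbonyl carbon. Among the measured compounds shown here, no measured step swaps a phenyl for a fused bicyclic group, so the bearing steps are indirect: the aryl swaps a 120-fold higher number from compound 1 to compound 2 (2.07 log units; beyond the scatter) and a 53-fold higher number from compound 1 to compound 3 (1.73 log units; beyond the scatter) were large, while the substituent swap a 2.2-fold lower number from compound 2 to compound 3 (0.34 log units; beyond the scatter) was modest. A step of modest size is therefore expected, with direction uncertain, leaning slightly lower, a 1.6-fold lower number from compound 3 to compound 4 (0.20 log units; within the scatter). For compound 4 the estimate in this assay is 400 nM, within 80 nM to 2000 nM.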

Compound 4, maximal plasma concentration: 300 nM
Compound 4: the middle estimate sits 1.3-fold (0.12 log units) above what was measured, within the range that was stated.
By their numbers in this assay, from the lowest: compound 1; then compound 4; then compound 3; then compound 2.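

In this assay the fused 5-chloro-1-methyl-1H-indol-6-yl group on the carbonyl carbon stays far from the low number of compound 1 (a 25-fold higher number from compound 1 to compound 4 (1.40 log units; beyond the scatter)). It still loses modestly against both 2-chloro-5-substituted phenyl groups (a 2.1-fold lower number from compound 3 to compound 4 (0.33 log units; beyond the scatter); a 4.7-fold lower number from compound 2 to compound 4 (0.67 log units; beyond the scatter)), so a fused ring system is accommodated here without matching the cyclopropyl compound. Open, as far as these compounds go, is whether a hydrogen or an ethyl in place of the methyl on the indole nitrogen shifts exposure, and whether a morpholine in place of pyrrolidin-1-yl does. Nothing available explains these differences.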